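A few compounds are considered here, and "the series" means these few. Any claim that something is new, unique, unknown or untested is made for them only; others in the source may bear on it.

Three analogues built on the shared core were examined in an ADME assay on L132 cells (Homo sapiens) for cytotoxicity, read by MTT assay, with a stated time of 48 h; on this read-out lower numbers stand for stronger inhibition and higher numbers for weaker inhibition. Compound 1 `C/C(=C\CC/C(C)=C/CC[C@@H]1[C@@]2(C)CCC(=O)C(C)(C)[C@H]2CC[C@@]1(C)O)CC/C=C(\C)C(=O)OCc1cn(C[C@@H]2O[C@H](n3ccc(=O)[nH]c3=O)C[C@H]2O)nn1` gives 148000 nM in this assay. Compound 2 `C/C(=C\CC/C(C)=C/CC[C@@H]1[C@@]2(C)CCC(=O)C(C)(C)[C@H]2CC[C@@]1(C)O)CC/C=C(\C)C(=O)OCc1cn(-c2ccccc2C)nn1` returns only a limit of this assay, reported as > 150000 nM. Compound 3 `C/C(=C\CC/C(C)=C/CC[C@@H]1[C@@]2(C)CCC(=O)C(C)(C)[C@H]2CC[C@@]1(C)O)CC/C=C(\C)C(=O)OCc1cn(C[C@@H]2O[C@H](n3ccc(=O)[nH]c3=O)[C@H]3OC(C)(C)O[C@H]32)nn1` likewise returns only a limit, reported as > 150000 nM. Compound 2 thus stands at the limit itself, one of the two values covered by the limit of > 150000 nM in this assay, at which 2 of the 3 values shown sit. Compound 4 `C/C(=C\CC/C(C)=C/CC[C@@H]1[C@@]2(C)CCC(=O)C(C)(C)[C@H]2CC[C@@]1(C)O)CC/C=C(\C)C(=O)OCc1cn(-c2cccc(O)c2)nn1` has not been measured; it differs from compound 2 by 3-hydroxyphenyl in place of 2-methylphenyl on an aromatic nitrogen. Among the compounds with values here, no measured pair differs in a single place, so no step size can be drawn from the data. Compound 4 is expected to remain close to the limit, with a step of a number no higher from compound 2 to compound 4 (the limit leaves the size open) that amounts to none beyond the scatter. The estimate for compound 4 in this assay is 150000 nM, between 90000 nM and 300000 nM.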

Compound 4, half-maximal inhibitory concentration: 146000 nM
Beside the measured number, compound 4's estimate is 1.0-fold (0.01 log units) above it; low and high end bracket the measured number.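

With 3-hydroxyphenyl on the aromatic nitrogen, compound 4 gives a number in this assay, 146000 nM. Compound 2, with 2-methylphenyl, gave only a limit in this assay. The step is an at least 1.0-fold lower number from compound 2 to compound 4 (0.01 log units; that floor lies within the scatter). Its true size cannot be read, since only a floor can be drawn from the limit held by compound 2: the limit of > 150000 nM in this assay, at which 2 of the 4 values shown sit.

On these data alone, it remains open whether the hydroxyl or its place on the phenyl ring matters in this assay, and what an amine or a carboxylic acid there would give.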